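The source may hold more compounds than are shown below. What is called first, only, known or untested is meant among the compounds shown, and "the series" means these compounds.

For the measured compounds named here, in a functional assay on RAW264.7 cells (Mus musculus) for inhibition, read by Griess assay, with a stated time of 24 h (a lower number here means a stronger inhibitor, a higher number a weaker inhibitor), compound 2 `CC(=O)S[C@]12CCC[C@H]1C(=O)NC2=O` gives 59200 nM, the lowest number so far, while compound 1 `CC(=O)S[C@]12CC[C@H](O)[C@H]1C(=O)NC2=O` gives 833000 nM. Compound 3 `CC(=O)SC1CC[C@]2(SC(C)=O)C(=O)NC(=O)[C@H]12` differs from compound 2 by one change: acetylsulfanyl in place of hydrogen on a saturated ring carbon. Going by the values given here, the only measured step, a 14-fold lower number from compound 1 to compound 2 (1.15 log units; beyond the scatter), is large, but it exchanges hydroxy for hydrogen on a saturated ring carbon. Among the compounds with values here, no measured step adds acetylsulfanyl, so the direction remains open, and no step beyond the scatter is expected in this assay. For compound 3 the estimated value is 50000 nM, with an expected range of 12000 nM to 200000 nM. The expected step is a 1.2-fold lower number from compound 2 to compound 3 (0.07 log units; within the scatter).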

Compound 3, half-maximal inhibitory concentration: 19800 nM
The estimate for compound 3 lay 2.5-fold (0.40 log units) above the measured number; measured number inside the range.
By their numbers in this assay, from the lowest: compound 3; then compound 2; then compound 1.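

In this assay this saturated ring carbon takes acetylsulfanyl with a 3.0-fold lower number from compound 2 to compound 3 (0.48 log units; beyond the scatter) and no loss, so a group of 4 heavy atoms is tolerated here. The same carbon bearing hydroxy in compound 1 gives 833000 nM against compound 3 at 19800 nM in this read-out, so the outcome at this position depends on the group placed there. On these data alone, whether an amine, a carboxylic acid or a longer chain on this carbon would lower the number further remains open. Nothing at hand accounts for the step.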